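Bicyclic alcohol in place of oxanyl on the amide nitrogen

The source may hold more compounds than are shown below. What is called first, only, known or untested is meant among the compounds shown, and "the series" means these compounds.

Compound 1 `CNC(=O)c1cc(C(=O)N[C@H]2CC[C@H](O)CC2)n([C@@H](C)c2ccc(Cl)cc2)n1`: 3.7
Compound 2 `CNC(=O)c1cc(C(=O)NC2CCOCC2)n([C@@H](C)c2ccccc2)n1`: 3.6

Two compounds sharing the same core have been characterised in a physicochemical assay for lipophilicity; on this read-out lower numbers stand for lower lipophilicity and higher numbers for higher lipophilicity. Compound 1 gives 3.7 in this assay. Compound 2 gives 3.6 in this assay, the lower of the two numbers, though its nearest neighbour, compound 1, lies only within the scatter above it, so the two cannot be ordered on this read-out. Among the compounds with values here, the two differ in more than one place, and no single step between them is recorded.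

Compound 3 `CNC(=O)c1cc(C(=O)N[C@H]2[C@@H]3C[C@@H](O)C[C@@H]32)n([C@@H](C)c2ccccc2)n1` has not yet been measured in this assay. It is derived from compound 2 by the change (a group of 7 heavy atoms (6 carbon, 1 oxygen; one three-membered non-aromatic ring of carbon only, one five-membered non-aromatic ring of carbon only) in place of a group of 6 heavy atoms (5 carbon, 1 oxygen; one six-membered non-aromatic ring with 1 hetero atom), on an amide-type nitrogen). Within the data shown here, no measured pair shows this same change, so the expected size of the step rests on the structural change alone. A small downward step from compound 2 to compound 3 is expected, one that may well stay within the scatter: a number 0.30 log units lower from compound 2 to compound 3 (within the scatter). Compound 3 is therefore estimated to give 3.3 in this assay, with a range from 2.8 to 3.8.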

Compound 3, distribution coefficient: 3.2
The estimate for compound 3 lay 0.10 log units above the measured number; the measured number falls inside the stated range.
By their numbers in this assay, from the lowest: compound 3; then compounds 2 and 1 (each within the scatter of the next).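

On the amide-type nitrogen, putting the group with one three-membered and one five-membered carbon ring in place of oxan-4-yl gives, in this assay, a number 0.40 log units lower from compound 2 to compound 3 (beyond the scatter), a modest step and the first one at this position that can be read at all. Within the data shown here, compounds 1 and 2 differ in more than one place and could not be ordered on this read-out, so this single exchange provides the first evidence that the group on this nitrogen can shift the number beyond the scatter. The exchange alters several things at once: the ring system changes, the heavy-atom count goes from 6 to 7, the entering group has 1 hydrogen-bond donor where oxan-4-yl has 0 hydrogen-bond donors, and 4 defined stereocentres appear, and no measurement here explains the step.

The compounds shown cannot separate these contributions, so it remains open whether the hydroxyl or the carbon framework accounts for the step, as a comparison with the same framework lacking the hydroxyl would show. As far as these compounds go, how a primary amine or a carboxylic acid on this nitrogen would read in this assay, and whether another stereoisomer of the entering group would give the same step, also stays unknown.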